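Bromo on the core of compound 1

The compounds below may be only part of what the source reports. "The series", "measured", "known", "first", "only" and "open" are said of these compounds alone.

Measured values:
- compound 1 `Cn1cc(C2CC(c3ccccc3)=NN2C(=O)c2cccnc2)c2ccccc21` gives 4630 nM
- compound 2 `COc1ccc(C(=O)N2N=C(c3ccccc3)CC2c2cn(C)c3ccccc23)cn1` gives 3130 nM
- compound 3 `Cn1cc(C2CC(c3ccccc3)=NN2C(=O)c2ccncc2)c2ccccc21` gives 630 nM

In a functional assay on HepG2 cells (Homo sapiens) for inhibition, read by MTT assay, with a stated time of 48 h (on this read-out lower numbers stand for stronger inhibition of growth and higher numbers for weaker inhibition of growth), compound 1 (4630 nM) sits at the high end of the numbers. Its nearest neighbour shows a 1.5-fold lower number from compound 1 to compound 2 (0.17 log units; within the scatter) and its furthest shows a 7.3-fold lower number from compound 1 to compound 3 (0.87 log units; beyond the scatter) on the same scale.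

Compound 4 `Cn1cc(C2CC(c3ccccc3)=NN2C(=O)c2cccnc2)c2cc(Br)ccc21` is compound 1 with one change on the core (bromo in place of hydrogen on an aromatic carbon) and the rest unaltered. Going by the values given here, no measured step touches this ring. Among the compounds with values here, the closest precedent is a 1.5-fold lower number from compound 1 to compound 2 (0.17 log units; within the scatter) as a replacement of hydrogen on an aromatic carbon, although that one lies on a different ring. Within the data shown here, the larger moves, a 7.3-fold lower number from compound 1 to compound 3 (0.87 log units; beyond the scatter) and a 5.0-fold lower number from compound 2 to compound 3 (0.70 log units; beyond the scatter) in turn, come from exchanging the group on the carbonyl carbon, so they show only that numbers can shift beyond the scatter.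

On this thin basis, a small step is expected in this assay, with a lower number more likely than a higher one. The expected step is a 1.7-fold lower number from compound 1 to compound 4 (0.22 log units; within the scatter) as a working figure. Compound 4 is estimated at 2800 nM with an expected range from 900 nM to 6500 nM for now.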

Compound 4, concentration for 50% growth inhibition: 2520 nM
Compound 4: middle estimate off by 1.1-fold (0.05 log units), on the high side; measured number inside the range.
By their numbers in this assay, from the lowest: compound 3; then compounds 4, 2 and 1 (each within the scatter of the next).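

In this assay the only change shown on the core of compound 1 gives a 1.8-fold lower number from compound 1 to compound 4 (0.26 log units; within the scatter), so bromo in place of hydrogen on this aromatic carbon, part of a fused system of two rings, leaves the number within the scatter. Going by these compounds alone, this is the first reading at this position, and it shows that one bromine here does not produce a step of the kind seen on the carbonyl carbon, where the change gives a 7.3-fold lower number from compound 1 to compound 3 (0.87 log units; beyond the scatter). No measurement at hand explains the size of the bromo step or ties it to any property of the group.

Going by these compounds, whether this position stays as flat with other groups remains open, for example with an amine, a carboxylic acid or a longer chain such as n-butyl in place of bromo. Also open, on these data alone, is whether bromo on the core gives a similarly small step when the group on the carbonyl carbon is pyridin-4-yl, as in compound 3, or 6-methoxypyridin-3-yl, as in compound 2.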